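Notes on the methyl-to-ethyl step toward compound 4

This account rests on a few compounds, and the source may have more. Where it says the series, first, only, none or still open, it means among the compounds named here.

Measured compounds:
compound 1, `Cn1c(/C=C2\SC(=O)N(CC(=O)Nc3nc(-c4ccccc4)cs3)C2=O)nc2ccccc21`, 31400 nM
compound 2, `CCn1c(/C=C2\SC(=O)N(CC(=O)N3CCCC3)C2=O)nc2ccccc21`, 45100 nM
compound 3, `Cn1c(/C=C2\SC(=O)N(CC(=O)N3CCCC3)C2=O)nc2ccccc21`, a limit, > 50000 nM

All three were run in a functional assay on DU-145 cells (Homo sapiens) for inhibition, read by MTT assay, with a stated time of 48 h; a higher number here means a weaker inhibitor, a lower number a stronger inhibitor. Compound 1 gives 31400 nM, and compound 2 gives a number that lies within the scatter of it, so no order is claimed between these two. Compound 3 reached only the assay limit, > 50000 nM, and at that limit sits (the limit of > 50000 nM in this assay, at which 1 of the 3 values shown sits). The difference between compound 1 and compound 3 is not broken down here.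

Compound 2 and compound 3 differ in one place: methyl in place of hydrogen on a saturated chain carbon bound to an aromatic nitrogen. Among the measured compounds shown here, the step measured for it is an at least 1.1-fold lower number from compound 3 to compound 2 (0.04 log units; that floor lies within the scatter), a floor set by the limit of compound 3; it fixes only that the number did not rise.

Compound 4, `CCn1c(/C=C2\SC(=O)N(CC(=O)Nc3nc(-c4ccccc4)cs3)C2=O)nc2ccccc21`, is not yet measured. It stands to compound 1 as compound 2 stands to compound 3: methyl in place of hydrogen on a saturated chain carbon bound to an aromatic nitrogen, the same change at the same place. The step for compound 4 is therefore expected to be small, a 1.2-fold lower number from compound 1 to compound 4 (0.08 log units; within the scatter). For the measured compounds named here, this rests on the single measured instance of the change, an at least 1.1-fold lower number from compound 3 to compound 2 (0.04 log units; that floor lies within the scatter), and on compound 1 at 31400 nM as the anchor. Compound 4 is estimated at 26000 nM, between 12000 nM and 50000 nM.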

Compound 4, half-maximal inhibitory concentration: > 50000 nM
Compound 4: a limit, no number (the forecaster's own chance of this, stated with the estimate: 20%); middle value at least 1.9-fold (0.28 log units) away from the limit.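

In this assay compound 4 gives > 50000 nM, a limit of the assay and not a number, so the step to it can only be read as a floor: the limit of > 50000 nM in this assay, at which 2 of the 4 values shown sit. Carried to the core of compound 1, the change gives an at least 1.5-fold higher number from compound 1 to compound 4 (0.20 log units; that floor lies within the scatter); this shows that the number did not fall on this core, but it fixes no size for the step. Set beside the core of compound 3, the result neither establishes that the methyl-to-ethyl change carries over from one core to the other nor shows that it behaves differently, since both readings are floors: the same change on two cores in this assay, an at least 1.1-fold lower number (0.04 log units; that floor lies within the scatter) from compound 3 to compound 2 and an at least 1.5-fold higher number (0.20 log units; that floor lies within the scatter) from compound 1 to compound 4; the limit leaves it open whether they differ.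

Left open is how a longer chain such as propyl or butyl, in place of the methyl or ethyl on the aromatic nitrogen, would read on either core. Also open, from the compounds shown here alone, is whether a carboxylic acid or an amine at the end of the side chain, in place of the amide group carried by these compounds, would give numbers clear of the limit on both cores, so that the change could be compared as a measured step.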